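Swapping 2-fluorophenyl for pyridin-3-yl: the step to compound 4

The source may report more compounds than this note shows. Statements on the series, on what has been measured and on what is new or still open speak of the compounds shown alone.

Compound 1, `CCCCNc1nc(N)nnc1OCc1ccccc1OC`: 640 nM
Compound 2, `CCCCNc1nc(N)nnc1OCc1ccccc1F`: 560 nM
Compound 3, `CCC[C@H](CCO)Nc1nc(N)nnc1OCc1nccc(OC)c1OC`: 560 nM

Of the compounds shown here, three sharing one core have been measured in an assay on isolated protein for agonist activity at Toll-like receptor 8 (Homo sapiens); a lower number here means that less compound is needed, a higher number that more compound is needed for the effect. Compound 2 gives 560 nM, level with compound 3 at the digits shown; together they give the lowest of the three numbers, and compound 1 gives the highest, though all three lie within the usual scatter of one another. Within the data shown here, the only single-point step among them, a 1.1-fold lower number from compound 1 to compound 2 (0.06 log units; within the scatter), replaces methoxy with fluoro on an aromatic carbon and stays within the scatter.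

Compound 4, `CCCCNc1nc(N)nnc1OCc1cccnc1`, has not yet been measured in this assay. It differs from compound 2 by pyridin-3-yl in place of 2-fluorophenyl on a saturated chain carbon bound to an oxygen on an aromatic ring. Among the measured compounds shown here, no measured step exchanges an all-carbon aromatic ring for one with a hetero atom, so nothing among the three compounds speaks directly to this change. For the measured compounds named here, the one step at this position, from compound 1 to compound 2, changed nothing beyond the scatter, which gives weak reason to expect a modest effect here as well. For compound 4 a number near that of compound 2 is therefore estimated, with a 1.3-fold higher number from compound 2 to compound 4 (0.10 log units; within the scatter) as the expected step and a wide range to reflect the lack of a bearing precedent: 700 nM, between 300 nM and 1600 nM.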

Compound 4, half-maximal effective concentration: 590 nM
Beside the measured number, compound 4's estimate is 1.2-fold (0.07 log units) above it, within the range that was stated.
By their numbers in this assay, from the lowest: compounds 2, 3, 4 and 1 (each within the scatter of the next).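

In this assay, pyridin-3-yl in place of 2-fluorophenyl on a saturated chain carbon bound to an oxygen on an aromatic ring gives a 1.1-fold higher number from compound 2 to compound 4 (0.02 log units; within the scatter). Among these compounds, the earlier step at this position, a 1.1-fold lower number from compound 1 to compound 2 (0.06 log units; within the scatter), exchanged only one group on an all-carbon aromatic ring, whereas this one shows that a six-membered aromatic ring with a hetero atom and a hydrogen-bond acceptor can replace that ring with no change beyond the scatter. The data offer no account of why the number holds across this exchange.

Still open, on these data alone, is whether the same holds for other ring replacements at this position, such as pyridin-2-yl, pyridin-4-yl or a saturated cyclohexyl group, or for a ring carrying an amine or a carboxylic acid, since a change large enough to move the number beyond the scatter has yet to appear here. As far as these compounds go, it is also open whether pyridin-3-yl would give a comparable result when paired with a different chain on the shared core, such as the hydroxyl-bearing chain of compound 3.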